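This account rests on a few compounds, and the source may have more. Where it says the series, first, only, none or still open, it means among the compounds named here.

Measured so far in a functional assay on HepG2 cells (Homo sapiens) for cytotoxicity, read by MTT assay, with a stated time of 72 h; a higher number here means a weaker inhibitor, a lower number a stronger inhibitor:
compound 1, `O=C(COc1ccc(-c2cc(=O)c3ccccc3o2)cc1)NC1CCN(Cc2ccccc2)CC1`, gives 15500 nM
compound 2, `COc1ccc(CN2CCC(NC(=O)COc3ccc(-c4cc(=O)c5ccccc5o4)cc3)CC2)cc1`, gives 6800 nM

Compound 2 holds the lowest of the two numbers in this assay; its nearest neighbour is compound 1, and the step of a 2.3-fold lower number from compound 1 to compound 2 (0.36 log units; beyond the scatter) lies beyond the scatter. Compound 3, `N#Cc1ccc(CN2CCC(NC(=O)COc3ccc(-c4cc(=O)c5ccccc5o4)cc3)CC2)cc1`, has not yet been measured. It differs from compound 2 in one place: cyano in place of methoxy on an aromatic carbon. Within the data shown here, only one measured step touches that aromatic carbon, a 2.3-fold lower number from compound 1 to compound 2 (0.36 log units; beyond the scatter), which put a methoxy where hydrogen had been, a modest change. Exchanging that methoxy for a cyano has no parallel among the measured compounds, so the direction of any change is open. The step of a 1.0-fold higher number from compound 2 to compound 3 (0.01 log units; within the scatter) is expected to stay within the scatter. Compound 3 is therefore estimated at 7000 nM, with a range from 2500 nM to 20000 nM.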

Compound 3, half-maximal inhibitory concentration: 6700 nM
The estimate for compound 3 lay 1.0-fold (0.02 log units) above the measured number; measured number inside the range.
By their numbers in this assay, from the lowest: compounds 3 and 2 (each within the scatter of the next); then compound 1.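

In this assay the step from the 4-methoxybenzyl to the 4-cyanobenzyl group is a 1.0-fold lower number from compound 2 to compound 3 (0.01 log units; within the scatter), so this assay does not separate these two groups at this carbon. The nitrile also gives a 2.3-fold lower number from compound 1 to compound 3 (0.36 log units; beyond the scatter), which shows that the lower number seen with methoxy is not unique to methoxy: two different groups at this place both stand apart from the hydrogen of compound 1. No measurement shown here explains why the two groups read alike.

Going by these compounds, whether an amine or a carboxylic acid on this same carbon would also match compound 2 and compound 3 remains open. So does whether a longer chain in place of the benzyl link would keep the number at this level.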